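Cytotoxicity notes on the benzyl variation series

A few compounds are considered here, and "the series" means these few. Any claim that something is new, unique, unknown or untested is made for them only; others in the source may bear on it.

Compound 1 `COC(=O)c1ccc(NCc2cncn2Cc2cccc(F)c2)cc1-c1ccccc1` gives > 1000 nM in a toxicity assay on NIH3T3 cells (Mus musculus) for cytotoxicity, read by resazurin assay; on this read-out higher numbers stand for an effect only at larger amounts of compound and lower numbers for an effect already at smaller amounts; this is a limit of the assay, not a number.
Compound 2 `COC(=O)c1ccc(NCc2cncn2Cc2ccc(-c3ccccc3)cc2)cc1-c1ccccc1` gives > 1000 nM in this assay; again a limit, not a number.
Compound 3 `COC(=O)c1ccc(NCc2cncn2Cc2ccc(OC)cc2)cc1-c1ccccc1` gives "not determined" (no result reported) in this assay, so no value is known for it.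

Compound 3 therefore stands nowhere on the numbers shown: it has no result, and the two other values in this assay are limits. For the measured compounds named here, the only step among measured compounds, a step that the two limits leave unreadable from compound 1 to compound 2, cannot be read, as both ends are limits.

Compound 4 `COC(=O)c1ccc(NCc2cncn2Cc2cccc(C#N)c2)cc1-c1ccccc1` differs from compound 3 by 3-cyanophenyl in place of 4-methoxyphenyl on a saturated chain carbon bound to an aromatic nitrogen. Going by the values given here, no measured step bears directly on this change; what the series shows is only that the two compounds with results sit at the limit (the limit of > 1000 nM in this assay, at which 2 of the 3 values shown sit). On that basis no cytotoxic effect within the tested range is expected for compound 4, and a limit rather than a number is the likelier report. Compound 4 is estimated at 3000 nM, within 1000 nM to 10000 nM.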

Compound 4, half-maximal effective concentration: > 10000 nM
Compound 4: no number, only a limit (the forecaster's own chance of this, stated with the estimate: 80%); at least 3.3-fold (0.52 log units) between middle value and limit.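

In this assay compound 4 gives > 10000 nM, a limit and not a number. The steps from compound 1 and compound 2 to compound 4 cannot be read, since all three values are limits. The compounds shown leave open at what concentration, if any, these benzyl variants become cytotoxic.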